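The source may report more compounds than this note shows. Statements on the series, on what has been measured and on what is new or still open speak of the compounds shown alone.

For the measured compounds named here, compound 2 `Fc1ccc(C2=CC3CNCC(C2)C3)cn1` gives 99 nM in an in vitro functional assay on SH-SY5Y cells for agonist activity at Neuronal acetylcholine receptor; alpha3/beta4 (Homo sapiens), read by FLIPR and calcium flux (on this read-out higher numbers stand for an effect only at larger amounts of compound and lower numbers for an effect already at smaller amounts), which is the highest of the two numbers known; its nearest neighbour is compound 1 `Clc1ccc(C2=CC3CNCC(C2)C3)cn1`, which gives 16 nM. Going by the values given here, the one measured step, a 6.2-fold higher number from compound 1 to compound 2 (0.79 log units; beyond the scatter), thus shows that the group on this aromatic carbon matters for the read-out. Compound 3 `C1=C(c2ccc(-c3ccccc3)nc2)CC2CNCC1C2` has not been measured; it differs from compound 2 by phenyl in place of fluoro on an aromatic carbon. Among the compounds with values here, no measured pair swaps fluoro for phenyl, so the only guide is the step from compound 1 to compound 2, where the larger halogen went with the lower number. A phenyl is far larger again, and nothing known tells whether that trend carries on or turns. Compound 3 is therefore expected to return a lower number than compound 2, at roughly a 2.5-fold lower number from compound 2 to compound 3 (0.39 log units; beyond the scatter). The estimate for compound 3 is 40 nM, with a range from 8 nM to 200 nM.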

Compound 3, half-maximal effective concentration: 10900 nM
Estimate against measurement, compound 3: 270-fold (2.44 log units) below; measured number above the stated range.
By their numbers in this assay, from the lowest: compound 1; then compound 2; then compound 3.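

In this assay, the carbon next to the ring nitrogen proves far less forgiving than the two halogens suggested: phenyl in place of fluoro gives a 110-fold higher number from compound 2 to compound 3 (2.04 log units; beyond the scatter) and phenyl in place of chloro gives a 680-fold higher number from compound 1 to compound 3 (2.83 log units; beyond the scatter) in the same series. Both steps exceed the change between the halogens, which was a 6.2-fold higher number from compound 1 to compound 2 (0.79 log units; beyond the scatter) only. The lower number that went with chloro rather than fluoro therefore does not carry on to a group of more heavy atoms, and compound 3 goes against any reading that more atoms here lower the number.

On these data alone, what a methyl, a methoxy or an amine on this carbon would give remains open, as does whether the rise sets in gradually between chloro and phenyl. Nothing available explains the rise seen with phenyl.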